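Swapping Hydroxy for Amino on a Shared Core

This account rests on a few compounds, and the source may have more. Where it says the series, first, only, none or still open, it means among the compounds named here.

Compound 1, `COc1ccc(-c2snnc2-c2cc(OC)c(OC)c(OC)c2)cc1[N+](=O)[O-]`: 13.4 nM in a functional assay on HL-60 cells (Homo sapiens) for antiproliferative activity; on this read-out lower numbers stand for stronger inhibition and higher numbers for weaker inhibition
Compound 2, `COc1ccc(-c2snnc2-c2cc(OC)c(OC)c(OC)c2)cc1`: 14.5 nM
Compound 3, `COc1ccc(-c2snnc2-c2cc(OC)c(OC)c(OC)c2)cc1O`: 1.5 nM

The three compounds share one core and differ at a single aromatic carbon. Compound 3 gives the lowest number of the three in this assay. The step of an 8.9-fold lower number from compound 1 to compound 3 (0.95 log units; beyond the scatter) and the step of a 9.7-fold lower number from compound 2 to compound 3 (0.99 log units; beyond the scatter) both lie beyond the scatter, whereas a 1.1-fold higher number from compound 1 to compound 2 (0.03 log units; within the scatter) lies within it, so of the three groups tried only hydroxy has moved the number.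

Compound 4, `COc1ccc(-c2snnc2-c2cc(OC)c(OC)c(OC)c2)cc1N`, has not been measured. Its change from compound 3 is amino in place of hydroxy on an aromatic carbon. For the measured compounds named here, no measured step swaps hydroxy for amino, so the bearing steps only show that removing hydroxy or replacing it with nitro raises the number. Compound 4 is therefore estimated at 3.5 nM, within 1 nM to 15 nM, a step of a 2.3-fold higher number from compound 3 to compound 4 (0.37 log units; beyond the scatter) expected.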

Compound 4, half-maximal inhibitory concentration: 1.8 nM
Estimate against measurement, compound 4: 1.9-fold (0.29 log units) above; the measured number falls inside the stated range.
By their numbers in this assay, from the lowest: compounds 3 and 4 (each within the scatter of the next); then compounds 1 and 2 (each within the scatter of the next).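

In this assay amino stands in for hydroxy at this aromatic carbon with no change beyond the scatter (a 1.2-fold higher number from compound 3 to compound 4 (0.08 log units; within the scatter)). Amino also gives lower numbers than hydrogen (an 8.1-fold lower number from compound 2 to compound 4 (0.91 log units; beyond the scatter)) and nitro (a 7.4-fold lower number from compound 1 to compound 4 (0.87 log units; beyond the scatter)), so the low number at this position is not unique to hydroxy. Nothing available explains why these two groups give such similar numbers.

From the compounds shown here alone, whether a methylamino or acetamido group at this carbon would keep the number this low remains open. So does whether a fluorine atom or a methyl group there would behave more like amino or like hydrogen.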